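A benzoxazole ketone in place of the pyrimidine ketone

The source may report more compounds than this note shows. Statements on the series, on what has been measured and on what is new or still open speak of the compounds shown alone.

Three ketones sharing one unsaturated chain were measured in an assay on isolated protein for inhibition of Fatty-acid amide hydrolase 1 (Homo sapiens); on this read-out lower numbers stand for stronger inhibition and higher numbers for weaker inhibition. Compound 1 `CCCCCCCC/C=C\CCCCCCC(=O)c1nnn(C)n1` gives 65 nM, compound 2 `CCCCCCCC/C=C\CCCCCCC(=O)c1ccncn1` gives 110 nM and compound 3 `CCCCCCCC/C=C\CCCCCCC(=O)c1ncc(-c2ccccn2)o1` gives 18 nM. Compound 2 thus holds the highest of the three numbers, within the scatter of compound 1 and beyond it from compound 3. Compound 4 `CCCCCCCC/C=C\CCCCCCC(=O)c1nc2ccccc2o1` carries 1,3-benzoxazol-2-yl in place of pyrimidin-4-yl on a carbonyl carbon. For the measured compounds named here, the one measured step that bears on such a swap, a 1.7-fold higher number from compound 1 to compound 2 (0.23 log units; within the scatter), stayed within the scatter, while compound 3, with another five-membered ring on the carbonyl carbon, shows the lowest number of the three. A move toward a lower number in this assay is therefore expected, a 4.4-fold lower number from compound 2 to compound 4 (0.64 log units; beyond the scatter). Compound 4 is estimated at 25 nM, between 6 nM and 100 nM.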

Compound 4, inhibition constant: 370 nM
Compound 4: the middle estimate sits 15-fold (1.17 log units) below what was measured; the whole stated range lies below it.
By their numbers in this assay, from the lowest: compound 3; then compounds 1 and 2 (each within the scatter of the next); then compound 4.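

At this place, on a carbonyl carbon whose other neighbour is a saturated chain carbon, 1,3-benzoxazol-2-yl raises the number in this assay, with a 3.4-fold higher number from compound 2 to compound 4 (0.53 log units; beyond the scatter) and a 5.7-fold higher number from compound 1 to compound 4 (0.76 log units; beyond the scatter) both lying beyond the scatter, unlike the earlier swap. A five-membered aromatic ring here therefore does not by itself bring a low number: compound 3 gives 18 nM and compound 4 gives 370 nM on the same read-out. No measurement given here explains the rise.

The compounds leave open whether an amine or a carboxylic acid on the 1,3-benzoxazol-2-yl group would lower the number again, and whether a longer chain would alter this step.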